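Trading the terminal phenyl for a propyl chain

A few compounds are considered here, and "the series" means these few. Any claim that something is new, unique, unknown or untested is made for them only; others in the source may bear on it.

Measured compounds:
- compound 1, `O=C(O)Cn1c(SCCOc2ccc3ccccc3c2)nc2ccccc21`: 2500 nM
- compound 2, `O=C(O)Cn1c(SCCCc2ccccc2)nc2ccccc21`: 475 nM

The two measured compounds were tested in an assay on HEK293 cells for displacement of a labelled ligand from prostaglandin D2 receptor 2 (Homo sapiens); on this read-out higher numbers stand for weaker inhibition and lower numbers for stronger inhibition. Compound 2 holds the lower of the two numbers, with 475 nM in this assay, while compound 1 gives 2500 nM, a clearly higher number, and the gap between them lies beyond the usual scatter. Compound 2 thus stands as the stronger of the two on the numbers shown.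

Compound 3, `CCCCCCSc1nc2ccccc2n1CC(=O)O`, has not yet been measured. It differs from compound 2 in one place: propyl in place of phenyl on a saturated chain carbon, three bonds along the chain from a sulfur. The shared core and the acid-bearing chain are kept; only the tail beyond the sulfur changes, with the ring gone and a chain in its place.

For the measured compounds named here, because compound 2 gives 475 nM with its phenyl still present, and no measured pair shows what removing that ring does, the step for compound 3 is estimated rather than derived. The step from compound 2 to compound 3 is expected to be a loss, a 3.2-fold higher number from compound 2 to compound 3 (0.50 log units; beyond the scatter), likely beyond the scatter. Compound 3 is therefore estimated at 1500 nM in this assay, within a range from 500 nM to 5000 nM.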

Compound 3, half-maximal inhibitory concentration: 1360 nM
Compound 3: middle estimate off by 1.1-fold (0.04 log units), on the high side; low and high end bracket the measured number.
By their numbers in this assay, from the lowest: compound 2; then compounds 3 and 1 (each within the scatter of the next).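

In this assay, for the compounds shown here, propyl in place of phenyl on a saturated chain carbon, three bonds along the chain from a sulfur, gives a 2.9-fold higher number from compound 2 to compound 3 (0.46 log units; beyond the scatter), a modest loss that lies beyond the scatter and is the first single-place change that can be read. It shows that the phenyl is not required for a measurable number at this position, since the all-chain tail of compound 3 still gives a value in this assay, but that the phenyl-bearing tail of compound 2 gives the lower number of the pair. Nothing in the data shown accounts for this step.

What the compounds shown leave open is whether the loss follows from removing a ring as such or from removing an aromatic ring, which a cyclohexyl group at the same place would separate, and whether a longer chain would change the number in either direction. Also open, from the compounds shown here alone, is how a terminal amine or a fluorine on the phenyl would behave here, and whether this single step would hold on any other core.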